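A Hydroxyphenyl Gives Way to a Pyrrolidine

The source may hold more compounds than are shown below. What is called first, only, known or untested is meant among the compounds shown, and "the series" means these compounds.

Among the measured compounds shown here, compound 1 `Oc1ccc(CNc2cc(C(F)(F)F)cc3[nH]ncc23)cc1` is the only compound in this set for which a number exists: in an assay for inhibition of Tryptophan 2,3-dioxygenase (Homo sapiens), with stated times of 10 min and 60 min (on this read-out lower numbers stand for stronger inhibition and higher numbers for weaker inhibition), compound 1 gives 2550 nM. Compound 2 `O=[N+]([O-])c1ccc(CNc2cc(C(F)(F)F)cc3[nH]ncc23)cc1` reaches only a limit of this assay, > 100000 nM. Compound 3 `CC(C)n1ncc2c(NCc3ccccc3[N+](=O)[O-])cc(C(F)(F)F)cc21` likewise reaches only a limit, > 100000 nM. For the measured compounds named here, the one measured step, an at least 39-fold higher number from compound 1 to compound 2 (1.59 log units; beyond the scatter), rests on the limit of > 100000 nM in this assay, at which 2 of the 3 values shown sit, and shows that exchanging the hydroxy group for nitro on the aromatic carbon is costly.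

Compound 4 `FC(F)(F)c1cc(NC[C@H]2CCCN2)c2cn[nH]c2c1` differs from compound 1 by pyrrolidin-2-yl in place of 4-hydroxyphenyl on a saturated chain carbon bound to a nitrogen on an aromatic ring. Going by the values given here, the step from compound 1 to compound 2 is the only measured step that bears on this change, and it concerns the hydroxy group alone; compound 4 keeps a hydrogen-bond donor and a hydrogen-bond acceptor but gives up the six-membered aromatic ring entirely, a change no measured pair covers. Among the compounds with values here, because the only comparison available, an at least 39-fold higher number from compound 1 to compound 2 (1.59 log units; beyond the scatter), points to a large loss when the hydroxy group is altered, the account expects a weaker number for compound 4, though with wide uncertainty. The expected step is a 4.7-fold higher number from compound 1 to compound 4 (0.67 log units; beyond the scatter). For compound 4 the estimate in this assay is 12000 nM, within a range from 2500 nM to 60000 nM.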

Compound 4, half-maximal inhibitory concentration: 6090 nM
Compound 4: middle estimate off by 2.0-fold (0.29 log units), on the high side, within the range that was stated.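

The step from 4-hydroxyphenyl to pyrrolidin-2-yl on a saturated chain carbon bound to a nitrogen on an aromatic ring is a 2.4-fold higher number from compound 1 to compound 4 (0.38 log units; beyond the scatter), and in this assay it is a modest one. Among the compounds shown here, this is the first sign that a six-membered aromatic ring of carbon only is not required at this position for a measurable number, since a five-membered non-aromatic ring with 1 hetero atom also gives one. The earlier compounds showed only the exchange of hydroxy for nitro, an at least 39-fold higher number from compound 1 to compound 2 (1.59 log units; beyond the scatter), which ends at a limit of the assay and so gives no size for that loss, and compound 4 now provides a second true number: the limit of > 100000 nM in this assay, at which 2 of the 4 values shown sit.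

The compounds shown leave open whether the defined stereocentre of pyrrolidin-2-yl matters, since the opposite configuration does not appear among them. They also leave open how a piperidin-2-yl ring, an open-chain amine or a carboxylic acid on the phenyl ring would read at this position, so the tolerance seen here rests on a single replacement.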